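The compounds below may be only part of what the source reports. "The series", "measured", "known", "first", "only" and "open" are said of these compounds alone.

Measured so far in an ADME assay on Vero cells (Chlorocebus sabaeus) for cytotoxicity, read by MTT assay; on this read-out higher numbers stand for lower toxicity in this test and lower numbers for higher toxicity in this test:

- compound 2 `Cn1nc(C(F)(F)F)cc1C(=O)Nc1ccc(S(=O)(=O)n2ccc3ccccc32)cc1`: 13000 nM
- compound 3 `Cn1nc(C(F)(F)F)cc1C(=O)Nc1ccc(S(=O)(=O)N2CCCCC2C(=O)OC(C)(C)C)cc1`: 38000 nM
- compound 1 `O=C(O)c1ccccc1-n1nc(C(F)(F)F)cc1C(=O)Nc1ccc(S(=O)(=O)N2CCCC2)cc1`: "not determined" (no result reported)

Compound 2 gives the lowest number of the two reported, which in this assay means the higher toxicity of the pair. Its nearest neighbour is compound 3, whose value lies beyond the scatter of compound 2, so the two are distinguishable on this read-out. Compound 1 contributes nothing to the comparison, as no number was obtained for it.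

The next compound in the series is compound 4 `Cn1nc(C(F)(F)F)cc1C(=O)Nc1ccc(S(=O)(=O)N2CCC(O)CC2)cc1`. Relative to compound 2 the change is 4-hydroxypiperidin-1-yl in place of 1H-indol-1-yl on a sulfonyl sulfur. The sulfonyl sulfur and the rest of the shared core are untouched.

Going by the values given here, no pair of measured compounds isolates this exchange, so nothing measured fixes its size. Compound 3, the only other sulfonamide with a six-membered non-aromatic ring on the sulfonyl sulfur, sits at the less toxic end of the two numbers. For compound 4 a step of a 2.3-fold higher number from compound 2 to compound 4 (0.36 log units; beyond the scatter) toward a higher number is expected, modest in size. Compound 4 is estimated at 30000 nM, with a range from 12000 nM to 80000 nM.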

Compound 4, half-maximal cytotoxic concentration: 274000 nM
Estimate against measurement, compound 4: 9.1-fold (0.96 log units) below, and the stated range ends below it.
By their numbers in this assay, from the lowest: compound 2; then compound 3; then compound 4.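

In this assay, the exchange of 1H-indol-1-yl for 4-hydroxypiperidin-1-yl on a sulfonyl sulfur gives a 21-fold higher number from compound 2 to compound 4 (1.32 log units; beyond the scatter) with the shared core unchanged. Going by these compounds alone, this is the first step that isolates a single place, and its large size shows that the group on the sulfonyl sulfur can strongly shift this read-out. Nothing available explains the size of the step.

The exchange removes both aromatic rings and brings in a non-aromatic ring with a hydroxyl group, so the compounds shown do not separate the contribution of the ring from that of the hydroxyl. Plain piperidin-1-yl would bear on that question, as would 4-aminopiperidin-1-yl or morpholin-4-yl, but none of these groups is among the compounds shown.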